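The compounds below may be only part of what the source reports. "The series", "measured", "known", "first", "only" and "open" are said of these compounds alone.

Compound 3 `Nc1cccc(-c2cn3nc(-c4ccc(Cl)cc4)sc3n2)c1` sits at a limit of a functional assay on L1210 cells (Mus musculus) for inhibition, read by cell counting, with a stated time of 2 days; on this read-out lower numbers stand for stronger inhibition and higher numbers for weaker inhibition: compound 3 gives >= 250000 nM, which is a limit and not a number. Compound 1 `Nc1cccc(-c2cn3nc(-c4cccs4)sc3n2)c1` likewise gives only a limit in this assay, > 250000 nM. Compound 2 `CCc1ccc(-c2nn3cc(-c4cccc(N)c4)nc3s2)cc1` gives 6000 nM in this assay. The step of an at least 41-fold higher number from compound 2 to compound 3 (1.61 log units; beyond the scatter) is large; the step that the two limits leave unreadable from compound 1 to compound 3 cannot be read because of the limit of > 250000 nM in this assay, at which 1 of the 3 values shown sits, and (the limit of >= 250000 nM in this assay, at which 1 of the 3 values shown sits). Compound 4 `Nc1cccc(-c2cn3nc(-c4ccc(F)cc4)sc3n2)c1` differs from compound 3 by fluoro in place of chloro on an aromatic carbon. For the measured compounds named here, no measured step exchanges two halogens; the nearest comparison, an at least 41-fold higher number from compound 2 to compound 3 (1.61 log units; beyond the scatter), sets ethyl against chloro. Compound 4 is therefore expected to remain near the limit, with the step of an at least 1.6-fold lower number from compound 3 to compound 4 (0.22 log units; that floor lies within the scatter) expected to carry little weight. Compound 4 is estimated at 150000 nM, within 15000 nM to 300000 nM.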

Compound 4, half-maximal inhibitory concentration: >= 250000 nM
Compound 4: only a limit was reported (the forecaster's own chance of this, stated with the estimate: 65%); at least 1.6-fold (0.22 log units) between middle value and limit.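

In this assay compound 4 gives >= 250000 nM, which is a limit and not a number. For the compounds shown here, with fluoro as with chloro at this position, para to a large group, no number emerges; the exchange of ethyl for fluoro gives an at least 41-fold higher number from compound 2 to compound 4 (1.61 log units; beyond the scatter), leaving ethyl as the only group here with a readable value. The steps among compound 1, compound 3 and compound 4 cannot be read: the limit of >= 250000 nM in this assay, at which 2 of the 4 values shown sit.

Still open, from the compounds shown here alone, is whether the readable value belongs to ethyl alone. A methyl group or a longer chain such as propyl at this position would address that.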